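A Carbonyl Substituent Exchanged Between Two Limits

This account rests on a few compounds, and the source may have more. Where it says the series, first, only, none or still open, it means among the compounds named here.

Compound 1, `C#CC(C)OC(=O)c1ccc(C(CC)(CC)c2ccc(OCCC(O)(CC)CC)c(C)c2)n1CC`, is the starting point. In a functional assay on Caco-2 cells (Homo sapiens) for antiproliferative activity, read by MTT assay, with a stated time of 48 h (on this read-out higher numbers stand for weaker inhibition and lower numbers for stronger inhibition), compound 1 gives > 50000 nM, which is a limit of the assay and not a number. Compound 2, `CCn1c(C(=O)Nc2cccc(C(F)(F)F)c2)ccc1C(CC)(CC)c1ccc(OCCC(O)(CC)CC)c(C)c1`, differs from compound 1 only at the carbonyl carbon. In this assay compound 2 gives > 50000 nM, again a limit rather than a number. The step that the two limits leave unreadable from compound 1 to compound 2 accordingly cannot be read in size. Both measured values sit at the limit of > 50000 nM in this assay, at which 2 of the 2 values shown sit.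

Compound 3, `CCn1c(C(=O)NC(C)C(=O)O)ccc1C(CC)(CC)c1ccc(OCCC(O)(CC)CC)c(C)c1`, is not yet measured. Its difference from compound 1 is (1-carboxyethyl)amino in place of (1-methylprop-2-yn-1-yl)oxy on a carbonyl carbon. Among the compounds with values here, the only measured step at the same carbonyl carbon, a step that the two limits leave unreadable from compound 1 to compound 2, is unreadable and so gives no size for this change. With both measured values sitting at the limit of > 50000 nM in this assay, at which 2 of the 2 values shown sit, the reading expected for compound 3 in this assay is most probably another limit, and the step that the limit leaves unreadable from compound 1 to compound 3 is expected to be small or unreadable. The estimate for compound 3 in this assay is 60000 nM, with a range from 20000 nM to 200000 nM, and the likeliest outcome is that only a limit is reported.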

Compound 3, half-maximal inhibitory concentration: 46500 nM
Estimate against measurement, compound 3: 1.3-fold (0.11 log units) above, and the stated range covers the measured number.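

Within the data shown here, compound 3 carries (1-carboxyethyl)amino on the carbonyl carbon, and in this assay compound 3 gives 46500 nM, the first reading at this position that is a number and not a limit. The exchange from the (1-methylprop-2-yn-1-yl)oxy group gives an at least 1.0-fold lower number from compound 1 to compound 3 (0.03 log units; that floor lies within the scatter), and the exchange from 3-(trifluoromethyl)phenyl on the amide-type nitrogen gives an at least 1.0-fold lower number from compound 2 to compound 3 (0.03 log units; that floor lies within the scatter). These two steps are floors and not sizes, because compound 1 and compound 2 both stand at a limit: the limit of > 50000 nM in this assay, at which 2 of the 3 values shown sit.

How far the true values of compound 1 and compound 2 lie beyond that limit stays unknown, so the compounds shown cannot tell whether the (1-carboxyethyl)amino group separates compound 3 from them by a small step or a large one. They also leave open which part of that group goes with the numerical reading, since nothing here compares it with a simple amine on the carbonyl carbon, with the methyl ester of the same chain, or with a longer chain ending in a carboxylic acid.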